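This account rests on a few compounds, and the source may have more. Where it says the series, first, only, none or still open, it means among the compounds named here.

Series notes. Among the compounds with values here, the shared core carries a branched chain whose terminal substituent varies; in a functional assay on CHO cells for antagonist activity at prostaglandin E2 receptor EP3 subtype (Homo sapiens), read by cAMP accumulation (a higher number here means a weaker inhibitor, a lower number a stronger inhibitor), the three measured members stand as follows. Compound 1 `CC(C)C(c1ccc(-c2ccc3cccc(F)c3c2)[nH]c1=O)N1CCCCS1(=O)=O` gives 122 nM. Compound 2 `CC(C)C(Cc1nnc[nH]1)c1ccc(-c2ccc3cccc(F)c3c2)[nH]c1=O` gives 17 nM. Compound 3 `CC(C)C(c1cnc(N)s1)c1ccc(-c2ccc3cccc(F)c3c2)[nH]c1=O` gives 39 nM, the second highest of the three numbers: the step was a 3.1-fold lower number from compound 1 to compound 3 (0.50 log units; beyond the scatter) and a 2.3-fold higher number from compound 2 to compound 3 (0.36 log units; beyond the scatter); the remaining measured step was a 7.2-fold lower number from compound 1 to compound 2 (0.86 log units; beyond the scatter).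

Compound 4 `CC(C)C(c1ncc[nH]1)c1ccc(-c2ccc3cccc(F)c3c2)[nH]c1=O` is the next member, not yet measured. The change is 1H-imidazol-2-yl in place of 2-amino-1,3-thiazol-5-yl on a saturated chain carbon bound to an aromatic carbon and a saturated chain carbon. Within the data shown here, two steps bear on it: the exchange of one five-membered aromatic ring for another, a 2.3-fold higher number from compound 2 to compound 3 (0.36 log units; beyond the scatter), which was modest, and a 3.1-fold lower number from compound 1 to compound 3 (0.50 log units; beyond the scatter), which brought in the ring that now leaves. Each five-membered aromatic ring tried so far gave a number within a narrow band below compound 1, so no step beyond the scatter is expected in this assay from this ring exchange. For compound 4 the estimate is 30 nM, with a range of 10 nM to 90 nM, which means an expected step of a 1.3-fold lower number from compound 3 to compound 4 (0.11 log units; within the scatter).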

Compound 4, half-maximal inhibitory concentration: 33 nM
For compound 4 the middle estimate is 1.1-fold (0.04 log units) below the measured one, within the range that was stated.
By their numbers in this assay, from the lowest: compounds 2, 4 and 3 (each within the scatter of the next, the first and the last beyond it); then compound 1.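

In this assay, the step of a 1.2-fold lower number from compound 3 to compound 4 (0.07 log units; within the scatter) shows that at this saturated chain carbon, 1H-imidazol-2-yl can stand in for 2-amino-1,3-thiazol-5-yl, with its sulfur and amino group gone and fewer hydrogen-bond acceptors, without a change beyond the scatter. The step of a 1.9-fold higher number from compound 2 to compound 4 (0.29 log units; within the scatter) also stays within the scatter, so compound 4 cannot be separated from compound 2 or compound 3, although those two differ beyond it, while a 3.7-fold lower number from compound 1 to compound 4 (0.57 log units; beyond the scatter) adds a third five-membered aromatic ring that reads apart from the six-membered non-aromatic ring of compound 1. No evidence at hand accounts for these readings.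

Still open, as far as these compounds go, is whether the ring hydrogen on nitrogen in 1H-imidazol-2-yl matters, which a methyl on that nitrogen would test. The compounds shown also say nothing of a carboxylic acid or a simple amine at this place.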